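The compounds below may be only part of what the source reports. "The series", "measured", "known", "first", "only" and "open" are said of these compounds alone.

In an assay on isolated protein with Bile acid receptor (Homo sapiens) as the target (on this read-out lower numbers stand for an effect already at smaller amounts and higher numbers for an effect only at larger amounts of compound), three compounds have been measured so far. Compound 1 `COC(=O)/C=C/c1cccc(N(Cc2ccc(/C=C/c3cc(C(F)(F)F)cc(C(F)(F)F)c3)cc2)C(=O)C2CCCCC2)c1` gives 1470 nM. Compound 2 `COC(=O)/C=C/c1cccc(N(Cc2ccc(/C=C/c3scnc3C)cc2)C(=O)C2CCCCC2)c1` gives 227 nM, and compound 3 `COC(=O)/C=C/c1cccc(N(Cc2ccc(/C=C/c3scnc3C)cc2)C(=O)C(C)C)c1` gives 228 nM. For the measured compounds named here, compound 3 thus stands second highest of the three numbers; its nearest neighbour is compound 2, and the single counted step between them, a 1.0-fold higher number from compound 2 to compound 3 (0.00 log units; within the scatter), lies within the scatter. The furthest is compound 1, whose number stands beyond the scatter above that of compound 3.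

Compound 4 `COC(=O)/C=C/c1cccc(N(Cc2ccc(-c3cccc(C)c3)cc2)C(=O)C(C)C)c1` has not yet been measured. It differs from compound 3 in one place: 3-methylphenyl in place of 2-(4-methyl-1,3-thiazol-5-yl)ethenyl on an aromatic carbon. Going by the values given here, the only measured step, from compound 2 to compound 3, concerns the group on the carbonyl carbon rather than the group changed here, so it bears little on this step. On these data alone, compounds 1 and 2 do differ at the same place as compounds 3 and 4; compound 1 gives 1470 nM while compound 2 gives 227 nM, which shows that a change at this place can move the number well beyond the scatter, though in which direction for compound 4 remains open. Compound 4 is therefore expected to give about 800 nM, with a range from 200 nM to 3000 nM. The step this estimate means, a 3.5-fold higher number from compound 3 to compound 4 (0.55 log units; beyond the scatter), is an expectation only, not a measurement.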

Compound 4, half-maximal effective concentration: 163 nM
Compound 4: middle estimate off by 4.9-fold (0.69 log units), on the high side, and the stated range ends above it.
By their numbers in this assay, from the lowest: compounds 4, 2 and 3 (each within the scatter of the next); then compound 1.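

In this assay, the aromatic carbon para to a large group accepts 3-methylphenyl in place of 2-(4-methyl-1,3-thiazol-5-yl)ethenyl with a step that lies within the scatter (a 1.4-fold lower number from compound 3 to compound 4 (0.15 log units; within the scatter)). Compounds 1 and 2, which differ at this same place, had shown only that their printed values lie well apart, with compound 1 at 1470 nM and compound 2 at 227 nM, whereas this pair shows that a change here need not move the number beyond the scatter, even though the five-membered aromatic ring with its hetero atoms, the double bond outside the rings and both hydrogen-bond acceptors all leave together. No measurement is available that would explain this result.

Because those features leave in a single change, the compounds shown cannot tell what each one contributes alone, nor what the methyl group on the new ring contributes. On these data alone, it also remains open how the number would respond to a phenyl ring carrying a carboxylic acid or an amine at this place, or to a 3-methylphenyl group attached through an ethenyl link.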